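Fluorobenzyl Added to the Core: Cytotoxicity Still Expected at the Limit

This account rests on a few compounds, and the source may have more. Where it says the series, first, only, none or still open, it means among the compounds named here.

Measured so far:
- compound 1, `Cc1c(Cc2ccccc2)c(=O)oc2cc(OCC(O)CNCC3CC3)ccc12`: a limit, > 100000 nM
- compound 2, `Cc1ccc2nc(NCC(O)COc3ccc4c(C)c(Cc5ccccc5)c(=O)oc4c3)sc2c1`: a limit, > 100000 nM
- compound 3, `Cc1cc(=O)oc2cc(OCC(O)CN3CCC(C(N)=O)CC3)ccc12`: a limit, > 100000 nM

In an ADME assay on A549 cells (Homo sapiens) for cytotoxicity, read by CellTiter-Glo (on this read-out higher numbers stand for lower toxicity in this test and lower numbers for higher toxicity in this test), compound 3 gives only a limit. All three measured compounds share this: the limit of > 100000 nM in this assay, at which 3 of the 3 values shown sit. For the measured compounds named here, the one measured step, a step that the two limits leave unreadable from compound 1 to compound 2, changes a group on an amine nitrogen, not the place altered here, and its size is not readable.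

Compound 4, `Cc1c(Cc2ccc(F)cc2)c(=O)oc2cc(OCC(O)CN3CCC(C(N)=O)CC3)ccc12`, differs from compound 3 by 4-fluorobenzyl in place of hydrogen on an aromatic carbon. Compound 1 and compound 2, which both carry a benzyl at that place, sit at the same limit as compound 3. Therefore no step beyond the scatter is expected, a step that the limit leaves unreadable from compound 3 to compound 4. Compound 4 is estimated at 150000 nM, with a range from 40000 nM to 500000 nM.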

Compound 4, half-maximal cytotoxic concentration: 89300 nM
For compound 4 the middle estimate is 1.7-fold (0.23 log units) above the measured one; the measured number falls inside the stated range.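

Compound 4 is the only compound shown that gives a number rather than a limit in this assay, and 4-fluorobenzyl at this aromatic carbon produces an at least 1.1-fold lower number from compound 3 to compound 4 (0.04 log units; that floor lies within the scatter). Compound 3 holds only a limit, so this step has a floor but no readable size. The set as a whole still sits mostly at that ceiling: the limit of > 100000 nM in this assay, at which 3 of the 4 values shown sit.

Left open is whether a chlorobenzyl or a longer alkyl chain at this place would also give a number. Also open is whether the fluorine plays any part, since the same core with plain benzyl and the same amide-bearing side chain is not among the compounds shown.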